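The compounds below may be only part of what the source reports. "The series", "measured", "known", "first", "only" and "open" are said of these compounds alone.

Measured so far in a functional assay on PC-3 cells (Homo sapiens) for antiproliferative activity, read by WST assay, with a stated time of 3 days; a lower number here means a stronger inhibitor, a higher number a weaker inhibitor:
compound 1 `CCCCOc1c(-c2cc(OC)c(OC)c(OC)c2)oc2ccccc2c1=O` gives 12800 nM
compound 2 `CCC(C)Oc1c(-c2cc(OC)c(OC)c(OC)c2)oc2ccccc2c1=O` gives 38600 nM
compound 3 `CCCC(C)Oc1c(-c2cc(OC)c(OC)c(OC)c2)oc2ccccc2c1=O` gives 49300 nM

Among these three numbers compound 2 stands second highest, close to compound 3 (a 1.3-fold higher number from compound 2 to compound 3 (0.11 log units; within the scatter)) and further from compound 1 (a 3.0-fold higher number from compound 1 to compound 2 (0.48 log units; beyond the scatter)). All three compounds share the same core and differ only in the group on the ring oxygen.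

Compound 4 `CCCN(CCC)CCCCOc1c(-c2cc(OC)c(OC)c(OC)c2)oc2ccccc2c1=O` is not yet measured. It differs from compound 2 in one place: 4-(dipropylamino)butyl in place of sec-butyl on an oxygen on an aromatic ring. The group that enters is an unbranched chain of the butyl type carrying a nitrogen at its far end.

For the measured compounds named here, only one measured step speaks to this change. Going from the unbranched butyl of compound 1 to the branched sec-butyl of compound 2 gave a 3.0-fold higher number from compound 1 to compound 2 (0.48 log units; beyond the scatter), so returning to an unbranched chain could recover about that much in this assay. Going by the values given here, the dipropylamino end has no counterpart among the measured compounds, so its effect is unknown.

Compound 4 is therefore expected to give a lower number than compound 2, a step estimated at a 3.9-fold lower number from compound 2 to compound 4 (0.59 log units; beyond the scatter), with a wide range: an estimate of 10000 nM, between 2000 nM and 50000 nM.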

Compound 4, half-maximal inhibitory concentration: 11600 nM
Compound 4: middle estimate off by 1.2-fold (0.06 log units), on the low side; low and high end bracket the measured number.
By their numbers in this assay, from the lowest: compounds 4 and 1 (each within the scatter of the next); then compounds 2 and 3 (each within the scatter of the next).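

In this assay the dipropylamino group at the far end of the unbranched butyl chain leaves compound 4 within the scatter of compound 1 (a 1.1-fold lower number from compound 1 to compound 4 (0.04 log units; within the scatter)), so this much larger group on the oxygen costs no measurable activity here. The branched chains stand apart from compound 4 by steps beyond the scatter (a 3.3-fold lower number from compound 2 to compound 4 (0.52 log units; beyond the scatter)) and (a 4.3-fold lower number from compound 3 to compound 4 (0.63 log units; beyond the scatter)), so among these four compounds the two with unbranched chains give the lower numbers, with or without the amine end. No measured evidence explains these numbers.

From the compounds shown here alone, whether the same holds for a shorter propyl or longer hexyl chain carrying the dipropylamino group stays open. So does the effect of a different amine at the chain end, such as dimethylamino or morpholine.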